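A few compounds are considered here, and "the series" means these few. Any claim that something is new, unique, unknown or untested is made for them only; others in the source may bear on it.

Measured compounds: compound 1 `CN(C)c1ccc(/C=C2\S/C(=N\c3nc(-c4ccc(Cl)cc4)cs3)NC2=O)cc1` and compound 2 `COc1ccc(/C=C2\S/C(=N\c3nc(-c4ccc(Cl)cc4)cs3)NC2=O)cc1`.

In a functional assay on HT-29 cells (Homo sapiens) for cytotoxicity, read by MTT assay, with a stated time of 72 h (on this read-out higher numbers stand for weaker inhibition and lower numbers for stronger inhibition), compound 1 gives 500 nM. In this assay compound 2 gives 400 nM. Among the measured compounds shown here, the two numbers lie within the scatter of each other, the step being a 1.3-fold lower number from compound 1 to compound 2 (0.10 log units; within the scatter), so compound 2 stands level with the only other measured compound.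

Compound 3 `O=C1N/C(=N/c2nc(-c3ccc(Cl)cc3)cs2)S/C1=C\c1ccc2ccccc2c1` differs from compound 2 by naphthalen-2-yl in place of 4-methoxyphenyl on a double-bonded chain carbon bound to a double-bonded ring carbon. For the measured compounds named here, the single measured step, a 1.3-fold lower number from compound 1 to compound 2 (0.10 log units; within the scatter), altered only the group on that same aromatic ring and stayed within the scatter, and no measured step exchanges the ring itself. Going by these compounds, on that thin basis the step in this assay from compound 2 to compound 3 is expected to stay within the scatter, as no change at the digits printed from compound 2 to compound 3 (within the scatter), with a wide range because the ring exchange is untested. Compound 3 is therefore estimated at 400 nM, between 130 nM and 1300 nM.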

Compound 3, half-maximal inhibitory concentration: 1800 nM
Beside the measured number, compound 3's estimate is 4.5-fold (0.65 log units) below it; measured number outside the range, above it.
By their numbers in this assay, from the lowest: compounds 2 and 1 (each within the scatter of the next); then compound 3.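

The double-bonded chain carbon bound to a double-bonded ring carbon turns out not to be indifferent to what it carries: in this assay the exchange of the whole aromatic group moves the number beyond the scatter, which the change on the ring of compound 1 did not do. Naphthalen-2-yl in place of 4-methoxyphenyl gives a 4.5-fold higher number from compound 2 to compound 3 (0.65 log units; beyond the scatter) and naphthalen-2-yl in place of 4-(dimethylamino)phenyl gives a 3.6-fold higher number from compound 1 to compound 3 (0.56 log units; beyond the scatter), so both steps point to weaker inhibition, and by similar modest sizes. Nothing available explains this loss.

Open, going by these compounds, is whether an unsubstituted phenyl or a pyridine ring at this position would stand level with compound 2 or with compound 3. Also open, on these data alone, is whether naphthalen-1-yl would behave as naphthalen-2-yl does.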